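From 4-methylphenyl to pyridin-2-yl in the writhing test

The source may hold more compounds than are shown below. What is called first, only, known or untested is meant among the compounds shown, and "the series" means these compounds.

For the measured compounds named here, compound 1 `Cc1ccc(-c2cc(C)n(S(=O)(=O)Oc3ccccc3)n2)cc1` gives the higher of the two numbers known so far in a functional assay on the whole organism for inhibition, with Mus musculus as the target, in the writhing test, with stated times of 3 days and 20 min, at a dose of 30 mg/kg by the oral route (a lower number here means less inhibition, a higher number more inhibition at the dose given (going by the name of the read-out)), where compound 1 reaches 50.7%. Compound 2 `O=S(=O)(Oc1ccccc1)n1nc(-c2ccccc2)cc1-c1ccccc1` gives 39.1% in this assay, a gap beyond the usual scatter. Compound 3 `Cc1cc(-c2ccccn2)nn1S(=O)(=O)Oc1ccccc1` differs from compound 1 in one place: pyridin-2-yl in place of 4-methylphenyl on an aromatic carbon. Going by the values given here, no measured pair shows what such a swap does, so the size of the step is open. The expected step for compound 3 is a number 8.7 percentage points lower from compound 1 to compound 3 (within the scatter), a modest loss or none at all. Compound 3 is estimated at 42%, within 22% to 60%.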

Compound 3, a percentage reported as inhibition, in the whole organism at one dose (the size of the read-out at that dose, not a potency): 15%
The estimate for compound 3 lay 27 percentage points above the measured number, and the stated range ends above it.
By their numbers in this assay, from the lowest: compound 3; then compound 2; then compound 1.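

In this assay, putting pyridin-2-yl in place of 4-methylphenyl gives a number 35.7 percentage points lower from compound 1 to compound 3 (beyond the scatter). This first measured pair at this position shows that the read-out depends strongly on which six-membered aromatic ring sits on this carbon: the entering ring has a ring nitrogen and a hydrogen-bond acceptor, and the leaving ring has neither. Nothing available bears on why the number falls.

On these data alone, it remains open whether the ring nitrogen or the lost methyl group accounts for the step. As far as these compounds go, the effect of a 4-methoxyphenyl group or an amine-bearing ring at this position is also open.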